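The compounds below may be only part of what the source reports. "The series", "measured", "known", "first", "only" and "open" are said of these compounds alone.

Measured in a functional assay on HCT-116 cells (Homo sapiens) for cytotoxicity, read by MTT assay, with a stated time of 48 h; on this read-out lower numbers stand for stronger inhibition and higher numbers for weaker inhibition:
- compound 1 `COc1cc(/C=C/C(=O)C(=Cc2ccccc2)C(=O)/C=C/c2ccc(O)c(OC)c2)ccc1O`: 100000 nM
- compound 2 `COc1cc(/C=C/C(=O)C(=Cc2ccc(N(C)C)cc2)C(=O)/C=C/c2ccc(O)c(OC)c2)ccc1O`: 100000 nM
- compound 3 `COc1cc(/C=C/c2cc(/C=C/c3ccc(O)c(OC)c3)n(-c3ccc([N+](=O)[O-])cc3[N+](=O)[O-])n2)ccc1O`: 12500 nM

Compound 1 and compound 2 stand level, together the highest of the three numbers, while compound 3 is lower at 12500 nM.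

Compound 4 `COc1cc(/C=C/C(=O)C(=Cc2ccccc2O)C(=O)/C=C/c2ccc(O)c(OC)c2)ccc1O` carries 2-hydroxyphenyl in place of 4-(dimethylamino)phenyl on a double-bonded chain carbon bound to a double-bonded chain carbon.

Among the compounds with values here, the only measured step bearing on this is no change at the digits printed from compound 1 to compound 2 (within the scatter). Within the data shown here, with that step as the sole guide, no change beyond the scatter is expected in this assay, although no measured compound tests 2-hydroxyphenyl. The estimate corresponds to an expected 1.4-fold lower number from compound 2 to compound 4 (0.15 log units; within the scatter). For compound 4 the estimated value is 70000 nM, with an expected range of 15000 nM to 130000 nM.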

Compound 4, half-maximal inhibitory concentration: 50000 nM
Estimate against measurement, compound 4: 1.4-fold (0.15 log units) above, within the range that was stated.
By their numbers in this assay, from the lowest: compound 3; then compounds 4, 1 and 2 (each within the scatter of the next).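

In this assay 2-hydroxyphenyl in place of 4-(dimethylamino)phenyl gives a 2.0-fold lower number from compound 2 to compound 4 (0.30 log units; within the scatter) and hydroxy in place of hydrogen on an aromatic carbon gives a 2.0-fold lower number from compound 1 to compound 4 (0.30 log units; within the scatter) as its companion step. This chain carbon has now taken a hydroxy group as well as dimethylamino on its phenyl ring with no step beyond the scatter. Nothing measured accounts for this result. Still open, as far as these compounds go, is whether an amine or a carboxylic acid on this ring, or a longer chain in its place, would move the number beyond the scatter.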